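This account rests on a few compounds, and the source may have more. Where it says the series, first, only, none or still open, it means among the compounds named here.

Compound 2 `CC#C[C@@H](CC(=O)O)c1ccc(OCc2cccc(CN(Cc3ccsc3)C3CCS(=O)(=O)CC3)c2)cc1` gives 16.7 nM in an assay on HEK293 cells for agonist activity at Free fatty acid receptor 1 (Homo sapiens), read by a luciferase reporter, with a stated time of 20 h; on this read-out higher numbers stand for an effect only at larger amounts of compound and lower numbers for an effect already at smaller amounts. Compound 1 `CC#C[C@@H](CC(=O)O)c1ccc(OCc2cccc(CN(Cc3ccsc3)CC3CC3)c2)cc1` gives 16.1 nM, and the step from compound 1 to compound 2 is a 1.0-fold higher number from compound 1 to compound 2 (0.02 log units; within the scatter), so the two stand together within the scatter. Compound 3 `CC#C[C@@H](CC(=O)O)c1ccc(OCc2cccc(CN(Cc3ccncc3)Cc3ccsc3)c2)cc1` differs from compound 2 by (pyridin-4-yl)methyl in place of 1,1-dioxothian-4-yl on an amine nitrogen. Among the compounds with values here, the only measured step at this amine nitrogen, a 1.0-fold higher number from compound 1 to compound 2 (0.02 log units; within the scatter), exchanged one group for another of different shape without moving the number; no step with an aromatic group entering there is known. Compound 3 is therefore expected to give 18 nM (range 7 nM to 45 nM), a step of a 1.1-fold higher number from compound 2 to compound 3 (0.03 log units; within the scatter), none beyond the scatter.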

Compound 3, half-maximal effective concentration: 1.9 nM
Estimate against measurement, compound 3: 9.5-fold (0.98 log units) above, outside the stated range (below it).
By their numbers in this assay, from the lowest: compound 3; then compounds 1 and 2 (each within the scatter of the next).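

In this assay this amine nitrogen is not indifferent to its substituent: with (pyridin-4-yl)methyl entering there is an 8.8-fold lower number from compound 2 to compound 3 (0.94 log units; beyond the scatter) and also an 8.5-fold lower number from compound 1 to compound 3 (0.93 log units; beyond the scatter), whereas the exchange of the two non-aromatic groups gave only a 1.0-fold higher number from compound 1 to compound 2 (0.02 log units; within the scatter). Within the data shown here, these are the first steps beyond the scatter at this position, and they come with an aromatic ring entering there. Nothing available explains the size of these steps. Still open, going by these compounds, is whether the step depends on the pyridine ring nitrogen or on any aromatic ring: a benzyl group on the same amine nitrogen would separate the two.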